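Amide nitrogen substituent in a phenoxyacetamide series

The compounds below may be only part of what the source reports. "The series", "measured", "known", "first", "only" and "open" are said of these compounds alone.

Compound 1 `Cc1ccc(OCC(=O)N(Cc2cccs2)c2c[nH]nc2C)cc1` is the reference point of this set. Within the data shown here, in an assay on HEK293 cells for agonist activity at transient receptor potential cation channel subfamily M member 8 (Homo sapiens), read by fluorescence and calcium flux, with a stated time of 15 min (on this read-out lower numbers stand for an effect already at smaller amounts and higher numbers for an effect only at larger amounts of compound), compound 1 gives 0.4 nM, the lowest of the three numbers measured so far. Its nearest neighbour on this read-out is compound 3 `CCN(Cc1cccs1)C(=O)COc1ccccc1C`, which in this assay gives 192 nM; the furthest is compound 2 `CCN(Cc1cccs1)C(=O)COc1ccc2c(c1)CCCC2`, which in this assay gives 689 nM. Both gaps to compound 1 lie beyond the scatter of the method. Among the measured compounds shown here, compounds 2 and 3 differ from compound 1 in more than one place, so no single step between measured compounds is available.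

Compound 4 `CCCN(Cc1cccs1)C(=O)COc1ccc(C)cc1` has not been measured. Against compound 1 the change is propyl in place of 3-methyl-1H-pyrazol-4-yl on an amide-type nitrogen. Compounds 2 and 3, which also carry a small alkyl chain rather than an aromatic ring on the amide nitrogen, both sit far from compound 1, so the expectation is a step toward higher numbers, well beyond the scatter, for the move from compound 1 to compound 4: a 300-fold higher number from compound 1 to compound 4 (2.48 log units; beyond the scatter) is the estimated size. Compound 4 is therefore expected to give about 120 nM in this assay, within an estimated range of 20 nM to 700 nM.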

Compound 4, half-maximal effective concentration: 40 nM
Compound 4: middle estimate off by 3.0-fold (0.48 log units), on the high side, within the range that was stated.
By their numbers in this assay, from the lowest: compound 1; then compound 4; then compound 3; then compound 2.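

Among these compounds, this pair gives the first reading of the amide nitrogen with everything else in the core held constant: in this assay, the change to propyl gives a 100-fold higher number from compound 1 to compound 4 (2.00 log units; beyond the scatter), a large step beyond the scatter. The substituent at this position alone therefore moves the read-out strongly, and 3-methyl-1H-pyrazol-4-yl is clearly favoured over propyl here, although compound 4, which has no ring on this nitrogen and no hydrogen-bond donor or acceptor in the new group, still gives a defined value of 40 nM in this series. Nothing measured here accounts for the size of this step.

The change swaps a ring for an open chain, removes a hydrogen-bond donor and acceptor, and shortens the substituent all at once, so this single step cannot assign its size to any one of these differences. Going by these compounds, whether phenyl, an unsubstituted pyrazol-4-yl, or a longer chain such as butyl or one ending in an amine on this nitrogen would fall nearer to compound 1 or to compound 4 remains open.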